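The source may hold more compounds than are shown below. What is called first, only, known or untested is meant among the compounds shown, and "the series" means these compounds.

Measured compounds in a physicochemical assay for solubility, in phosphate buffer, at pH 7.4; a higher number here means a more soluble compound, a lower number a less soluble compound:
Compound 1 `CCOC(=O)c1c(-c2ccc(OC)cc2)[nH]c2cccc(OC)c2c1=O` reaches only the assay limit, > 100000 nM.
Compound 2 `CCOC(=O)c1c(-c2cccc(OC)c2)[nH]c2cc(OC)ccc2c1=O` likewise reaches only the assay limit, > 100000 nM.
Compound 3 `CCOC(=O)c1c(-c2ccc(Cl)c(Cl)c2)[nH]c2cccc(OC)c2c1=O` gives a number, 39000 nM.

Among the compounds with values here, compound 3 thus holds the only numerical solubility value; the other two values sit at the limit, as noted in the limit of > 100000 nM in this assay, at which 2 of the 3 values shown sit. Within the data shown here, the single measured step that reaches compound 3 is an at least 2.5-fold lower number from compound 1 to compound 3 (0.40 log units; beyond the scatter), which moved the value from the limit down to a measured number.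

The next compound, compound 4 `CCOC(=O)c1c(-c2ccccc2)[nH]c2cccc(OC)c2c1=O`, differs from compound 3 only at the aryl group: phenyl in place of 3,4-dichlorophenyl on an aromatic carbon. That change undoes part of what the step from compound 1 to compound 3 introduced, without restoring the methoxy group of compound 1. On the strength of an at least 2.5-fold lower number from compound 1 to compound 3 (0.40 log units; beyond the scatter) a move back upward is expected in this assay, of a size that could return the value to, or close to, the limit. The estimate for compound 4 is therefore 80000 nM (range 35000 nM to 180000 nM), an expected step of a 2.1-fold higher number from compound 3 to compound 4 (0.31 log units; beyond the scatter).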

Compound 4, solubility: > 100000 nM
Compound 4: a limit, no number (the forecaster's own chance of this, stated with the estimate: 35%); middle value at least 1.2-fold (0.09 log units) from the limit.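

In this assay, phenyl in place of 3,4-dichlorophenyl on the aromatic carbon next to the ring nitrogen gives an at least 2.5-fold higher number from compound 3 to compound 4 (0.40 log units; beyond the scatter), so a measured number at this position does not need a replacement for the methoxy group alone to disappear: removing the two chlorines is enough to return to the limit. Compound 1 and compound 4 both stand at a limit, so the step between them cannot be read, and among compound 1, compound 3 and compound 4 only the 3,4-dichlorophenyl group gives a number. The size of the new step is only a bound because compound 4 sits at the limit: the limit of > 100000 nM in this assay, at which 3 of the 4 values shown sit.

Open, as far as these compounds go, is whether a single chlorine, at either ring position, already brings the value under the limit. Also open, from the compounds shown here alone, is how a carboxylic acid or an amine in place of the ethoxycarbonyl group would read in this assay.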